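The source may report more compounds than this note shows. Statements on the series, on what has been measured and on what is new or still open speak of the compounds shown alone.

Of the compounds shown here, two built on one shared core have been tested in a functional assay on the whole organism (strain albino) for inhibition, with Rattus norvegicus as the target, read by paw edema, with a stated time of 1 h, at a dose of 100 mg/kg by the oral route; on this read-out higher numbers stand for more inhibition at the one dose given (going by the name of the read-out) and lower numbers for less inhibition. Compound 2 `O=C(CSc1nc(-c2ccc(Cl)cc2)c(C(=O)O)c(=O)[nH]1)Nn1c(COc2ccc(Cl)cc2Cl)nc2ccccc2c1=O` gives 58.2% in this assay, the lower of the two numbers. Compound 1 `N#Cc1c(-c2ccc(O)cc2)nc(SCC(=O)Nn2c(COc3ccc(Cl)cc3Cl)nc3ccccc3c2=O)[nH]c1=O` carries a hydroxy group and a nitrile where compound 2 carries a chloro group and a carboxylic acid. In this assay compound 1 gives 63.6%; the two values lie within the usual scatter, so neither can be called stronger. Compound 3 `O=C(CSc1nc(-c2ccc(O)cc2)c(C(=O)O)c(=O)[nH]1)Nn1c(COc2ccc(Cl)cc2Cl)nc2ccccc2c1=O` is not yet measured and differs from compound 2 by hydroxy in place of chloro on an aromatic carbon. No single change of this kind has been measured, so the expected step is a number 1.8 percentage points higher from compound 2 to compound 3 (within the scatter), nothing beyond the scatter. Compound 3 is estimated to give 60%, between 46% and 74%.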

Compound 3, a percentage reported as inhibition, in the whole organism at one dose (the size of the read-out at that dose, not a potency): 36.4%
For compound 3 the middle estimate is 23.6 percentage points above the measured one, and the stated range ends above it.
By their numbers in this assay, from the lowest: compound 3; then compounds 2 and 1 (each within the scatter of the next).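

In this assay, among the compounds shown here, hydroxy in place of chloro on an aromatic carbon gives a number 21.8 percentage points lower from compound 2 to compound 3 (beyond the scatter) and is the first measured single change at this position. With the hydroxy kept, carboxy in place of cyano gives a number 27.2 percentage points lower from compound 1 to compound 3 (beyond the scatter) as well, so each of the two single changes leading to compound 3 lowers the number. Nothing measured here gives a reason for either step. As far as these compounds go, whether an amine or a methoxy group at the same place would keep the number up remains open, as does the effect of chloro alongside the nitrile.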